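Cyclopropyl to 1-Hydroxyethyl: Estimating Compound 4

The compounds below may be only part of what the source reports. "The series", "measured", "known", "first", "only" and "open" are said of these compounds alone.

Compound 1 `CC(C)c1ccccc1-c1nc(NCc2ccc(-c3cccnc3)cc2)c2occc2n1`: 80 nM
Compound 2 `Cc1cnc(-c2ccccc2C(C)C)nc1NCc1cccnc1`: 1300 nM
Compound 3 `Cc1cnc(-c2ccccc2C2CC2)nc1NCc1ccc(-c2cccnc2)cc1`: 180 nM

In an assay on a protein complex for inhibition of ubiquitin carboxyl-terminal hydrolase 1/WD repeat-containing protein 48 (Homo sapiens), read by fluorescence (on this read-out higher numbers stand for weaker inhibition and lower numbers for stronger inhibition), compound 3 gives 180 nM, the second highest of the three numbers. Compound 1 gives 80 nM, a lower number and beyond the scatter. Compound 2 gives 1300 nM, a higher number and well beyond the scatter. Compound 4 `Cc1cnc(-c2ccccc2C(C)O)nc1NCc1ccc(-c2cccnc2)cc1` differs from compound 3 by 1-hydroxyethyl in place of cyclopropyl on an aromatic carbon. For the measured compounds named here, no measured pair shows this change, and the expectation rests on the structural change alone. The expected step of a 1.9-fold higher number from compound 3 to compound 4 (0.29 log units; within the scatter) is a modest move toward weaker inhibition, with a real chance of no change beyond the scatter. Compound 4 is therefore estimated at 350 nM, with a range from 120 nM to 1200 nM.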

Compound 4, half-maximal inhibitory concentration: 2000 nM
Beside the measured number, compound 4's estimate is 5.7-fold (0.76 log units) below it; the measured number lies above the stated range.
By their numbers in this assay, from the lowest: compound 1; then compound 3; then compounds 2 and 4 (each within the scatter of the next).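

In this assay, 1-hydroxyethyl in place of cyclopropyl gives an 11-fold higher number from compound 3 to compound 4 (1.05 log units; beyond the scatter), the only single-place comparison among these compounds. Both groups hold 3 heavy atoms, so this position on the aromatic ring responds strongly to more than the count of heavy atoms. Nothing measured here explains the loss of inhibition. On these data alone, whether the oxygen or the lost ring matters more remains open. So does how a methoxy or 1-aminoethyl group would behave at this position.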